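A few compounds are considered here, and "the series" means these few. Any claim that something is new, unique, unknown or untested is made for them only; others in the source may bear on it.

Measured so far in an ADME assay (liver) for metabolic stability, with Liver microsome (Rattus norvegicus) as the target, using microsomes and NADPH, with a stated time of 30 min, tested at 1 uM; a higher number here means faster removal of the compound, a lower number slower removal:
compound 1 `Nc1ccc(S(=O)(=O)N2CCN(c3ncc(C(O)(C(F)(F)F)C(F)(F)F)cc3C#CC3CC3)CC2)cn1` gives 67 mL.min-1.g-1
compound 2 `CC(C)n1cc(-c2cc(C(O)(C(F)(F)F)C(F)(F)F)cnc2N2CCN(S(=O)(=O)c3ccc(N)nc3)CC2)cn1` gives 198 mL.min-1.g-1

Compound 2 stands highest of the two numbers in this assay; the nearest is compound 1, and the step is a 3.0-fold higher number from compound 1 to compound 2 (0.47 log units; beyond the scatter). Compound 3 `Nc1ccc(S(=O)(=O)N2CCN(c3ncc(C(O)(C(F)(F)F)C(F)(F)F)cc3-c3cc4ccccc4[nH]3)CC2)cn1` is not yet measured. It differs from compound 2 in one place: 1H-indol-2-yl in place of 1-isopropyl-1H-pyrazol-4-yl on an aromatic carbon. Among the measured compounds shown here, the only measured step that bears on it is the one from compound 1 to compound 2, which also exchanges the group at this same position and was modest in size. For the measured compounds named here, no measured pair covers an indolyl group, so the direction of the coming step is open. For compound 3 in this assay a step of a 1.3-fold lower number from compound 2 to compound 3 (0.12 log units; within the scatter) is expected. The estimated number for compound 3 is 150 mL.min-1.g-1, with a range from 60 mL.min-1.g-1 to 350 mL.min-1.g-1.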

Compound 3, intrinsic clearance in microsomes: 146 mL.min-1.g-1
Beside the measured number, compound 3's estimate is 1.0-fold (0.01 log units) above it; the range from low to high includes it.
By their numbers in this assay, from the lowest: compound 1; then compounds 3 and 2 (each within the scatter of the next).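

In this assay, 1H-indol-2-yl and 1-isopropyl-1H-pyrazol-4-yl on this aromatic carbon are not told apart (a 1.4-fold lower number from compound 2 to compound 3 (0.13 log units; within the scatter)), despite the different ring make-up and the hydrogen-bond donor on the indole. Both aromatic groups sit apart from 2-cyclopropylethynyl, with the indole also beyond the scatter (a 2.2-fold higher number from compound 1 to compound 3 (0.34 log units; beyond the scatter)), so among these three compounds only compound 1 stands lower. No measurement on hand gives a reason for these numbers. Open, going by these compounds, is how a plain phenyl or a 1-methyl-1H-indol-2-yl group would read here, and whether a saturated amine at this position would fall nearer compound 1.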